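Chain-end ester on the lactone series

The source may hold more compounds than are shown below. What is called first, only, known or untested is meant among the compounds shown, and "the series" means these compounds.

Measured in a functional assay on MOLT-4F cells (Homo sapiens) for antiproliferative activity; on this read-out higher numbers stand for weaker inhibition of growth and lower numbers for stronger inhibition of growth:
- compound 1 `COCCCCCCCCCCCCCCC/C=C1\CC(CO)(COC(=O)C(C)(C)C)OC1=O`: 0.498 ug/mL
- compound 2 `CC(C)(C)C(=O)OCC1(CO)C/C(=C\CCCCCCCCCCCCCCC=O)C(=O)O1`: > 10 ug/mL (a limit of the assay)
- compound 3 `CC(C)(C)C(=O)OCC1(CO)C/C(=C/CCCCCCCCCCCCCCC=O)C(=O)O1`: 2.02 ug/mL

Compound 1 has the lowest number shown. The nearest value is that of compound 3 at 2.02 ug/mL, and this gap lies beyond the scatter.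

Compound 4 `CC(C)(C)C(=O)OCCCCCCCCCCCCCCC/C=C1\CC(CO)(COC(=O)C(C)(C)C)OC1=O` changes the chain end of compound 1: (tert-butyl)carbonyl in place of methyl on an oxygen on a saturated carbon. In words, (tert-butyl)carbonyl stands in place of methyl on an oxygen on a saturated carbon, so methoxymethyl becomes (((tert-butyl)carbonyl)oxy)methyl.

One measured step alters this chain end: an at least 20-fold higher number from compound 1 to compound 2 (1.30 log units; beyond the scatter). It replaces methoxymethyl with formyl, which is a different group from the incoming one, so it is only a loose guide to size. The other step, an at least 4.9-fold lower number from compound 2 to compound 3 (0.69 log units; beyond the scatter), concerns double-bond configuration, and compounds 1 and 4 are drawn alike there, so it does not apply.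

Given the large step to compound 2 an at least 20-fold higher number from compound 1 to compound 2 (1.30 log units; beyond the scatter), a rise smaller than that one is expected in this assay. The estimated step is a 3.0-fold higher number from compound 1 to compound 4 (0.48 log units; beyond the scatter). For compound 4 the expected value is 1.5 ug/mL, with an estimated range from 0.35 ug/mL to 7 ug/mL.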

Compound 4, concentration for 50% growth inhibition: 0.605 ug/mL
For compound 4 the middle estimate is 2.5-fold (0.39 log units) above the measured one, within the range that was stated.
By their numbers in this assay, from the lowest: compounds 1 and 4 (each within the scatter of the next); then compound 3. At a limit, above all of these: compound 2.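

In this assay, the step to the bulkier chain end, ((tert-butyl)carbonyl)oxy in place of methoxy, stays inside the scatter, a 1.2-fold higher number from compound 1 to compound 4 (0.08 log units; within the scatter), so compounds 1 and 4 cannot be told apart here. Against that, an at least 16-fold lower number from compound 2 to compound 4 (1.21 log units; beyond the scatter), which places the large gap in this pair of chain ends on the formyl of compound 2, whereas the methoxymethyl and (((tert-butyl)carbonyl)oxy)methyl ends of compounds 1 and 4 read alike. The value of compound 2, > 10 ug/mL, is a limit of the assay.

Open, going by these compounds, is whether a free hydroxyl, a carboxylic acid or an amine at the chain end would read like compounds 1 and 4 or like compound 2. Also open, on these data alone, is whether the double-bond configuration of compound 3 would shift the number with a methoxy or ester chain end, or with a longer chain.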